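The source may hold more compounds than are shown below. What is called first, only, known or untested is meant among the compounds shown, and "the series" means these compounds.

Working notes on the series. Compound 1 `CCCN(CCC)c1c(CC)nc(-c2c(C)cc(C)cc2OC)n(CC)c1=O` gives 4 nM in an assay on IMR-32 cells for binding affinity to corticotropin-releasing factor receptor 1 (Homo sapiens) (on this read-out higher numbers stand for weaker inhibition and lower numbers for stronger inhibition), and compound 3 `CCCN(CCC)c1c(C)nc(-c2ccc(OC)cc2OC)n(CC2CC2)c1=O` gives 260 nM. Compound 2 `CCCN(CCC)c1c(C)nc(-c2c(C)cc(C)cc2OC)n(C)c1=O` gives 90 nM, the second highest of the three numbers; compound 3 stands nearest with a higher number and compound 1 furthest with a lower one, both gaps beyond the scatter. Among the compounds with values here, no two measured compounds differ in only one place, so no single step is isolated. Compound 4 `CCCN(CCC)c1c(C)nc(-c2c(C)cc(C)cc2OC)n(CCC)c1=O` is not yet measured; it differs from compound 2 by ethyl in place of hydrogen on a saturated chain carbon bound to an aromatic nitrogen. A lower number is expected because compound 1 gives 4 nM with longer chains, though compound 1 differs from compound 2 in two places. The expected step is a 3.6-fold lower number from compound 2 to compound 4 (0.56 log units; beyond the scatter). Compound 4 is estimated at 25 nM, within 8 nM to 80 nM.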

Compound 4, inhibition constant: 190 nM
Compound 4: middle estimate off by 7.6-fold (0.88 log units), on the low side, and the stated range ends below it.
By their numbers in this assay, from the lowest: compound 1; then compound 2; then compounds 4 and 3 (each within the scatter of the next).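

Within the data shown here, this gives the first isolated single-place step: in this assay, methyl to propyl on a saturated chain carbon bound to an aromatic nitrogen gives a 2.1-fold higher number from compound 2 to compound 4 (0.32 log units; beyond the scatter), a modest step towards weaker inhibition. At this position, with the rest of compound 2 unchanged, the longer chain alone therefore does not lower the number. No measurement shown accounts for this step.

The compounds shown leave open how a butyl chain or a chain ending in an amine would read at this position. On these data alone, whether the same change gives a similar step on the core of compound 1 also remains open.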